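The source may hold more compounds than are shown below. What is called first, only, known or untested is meant among the compounds shown, and "the series" means these compounds.

Of the compounds shown here, three sharing one core have been tested in a functional assay on A549 cells (Homo sapiens) for inhibition, read by MTT assay, with a stated time of 48 h; on this read-out higher numbers stand for weaker inhibition of growth and lower numbers for stronger inhibition of growth. Compound 1 (`Cn1cc(C2CC(c3ccccc3)=NN2C(=O)c2cccnc2)c2cc(Br)ccc21`) gives 1600 nM. Compound 3 (`COc1ccc(C2=NN(C(=O)c3cccnc3)C(c3cn(C)c4ccc(Br)cc34)C2)cc1`) gives 1190 nM, which lies within the scatter of compound 1. Compound 2 (`Cn1cc(C2CC(c3ccc(Br)cc3)=NN2C(=O)c2cccnc2)c2cc(Br)ccc21`) gives > 10000 nM, and this value is a limit of the assay. Compound 3 therefore stands level with compound 1, as one of the two compounds that return a number at all.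

Compound 4 (`COc1ccc(C2=NN(C(=O)c3cccnc3)C(c3cn(C)c4ccc(Br)cc34)C2)cc1OC`) differs from compound 3 in one place: methoxy in place of hydrogen on an aromatic carbon. A 4-methoxyphenyl becomes a 3,4-dimethoxyphenyl, with the new methoxy ortho to a methoxy group. Among the measured compounds shown here, the closest precedent is the same kind of exchange, methoxy in place of hydrogen, in a 1.3-fold lower number from compound 1 to compound 3 (0.13 log units; within the scatter), which stays within the scatter. The larger steps, an at least 6.2-fold higher number from compound 1 to compound 2 (0.79 log units; beyond the scatter) and an at least 8.4-fold lower number from compound 2 to compound 3 (0.92 log units; beyond the scatter), lie beyond the scatter, but both involve a bromo group, which plays no part in this change. They do show that substitution at this part of the molecule can matter, so the range is kept wide. No step beyond the scatter is expected in this assay, and the estimated step is a 1.2-fold higher number from compound 3 to compound 4 (0.07 log units; within the scatter). Compound 4 is estimated at 1400 nM, with an expected range from 500 nM to 4500 nM.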

Compound 4, concentration for 50% growth inhibition: 2380 nM
Beside the measured number, compound 4's estimate is 1.7-fold (0.23 log units) below it, within the range that was stated.
By their numbers in this assay, from the lowest: compounds 3, 1 and 4 (each within the scatter of the next). At a limit, above all of these: compound 2.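

In this assay, the 3,4-dimethoxyphenyl of compound 4 in place of the 4-methoxyphenyl gives a 2.0-fold higher number from compound 3 to compound 4 (0.30 log units; within the scatter), so a new methoxy on this ring, ortho to a methoxy group, leaves the number within the scatter, as the first methoxy did. Set against the plain phenyl, the two methoxy groups together give a 1.5-fold higher number from compound 1 to compound 4 (0.17 log units; within the scatter), which shows that on the listed compounds this ring carries two methoxy groups without a step beyond the scatter from compound 1. The bromo compound remains apart, since the 3,4-dimethoxyphenyl in place of the 4-bromophenyl gives an at least 4.2-fold lower number from compound 2 to compound 4 (0.62 log units; beyond the scatter), a step beyond the scatter that is read against a limit of the assay and not against a number: the limit of > 10000 nM in this assay, at which 1 of the 4 values shown sits.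

The compounds shown carry only methoxy and bromo on this ring, so they leave open whether an amine, a hydroxyl or a carboxylic acid there would stay with the methoxy compounds or go with compound 2. They also leave open how a longer chain such as ethoxy in place of the new methoxy would read in this assay.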